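The source may report more compounds than this note shows. Statements on the series, on what has been measured and on what is new or still open speak of the compounds shown alone.

Measured compounds:
compound 1 `COc1ccc(CNc2nc([Se]C)nc3ccccc23)cc1` gives > 100000 nM in a functional assay on HT-29 cells (Homo sapiens) for cytotoxicity, read by MTT assay, with a stated time of 72 h (on this read-out lower numbers stand for higher toxicity in this test and higher numbers for lower toxicity in this test), a limit.
compound 2 `CSc1ccc(CNc2nc([Se]C)nc3ccccc23)cc1` gives > 100000 nM in this assay, a limit.

In this assay compound 1 reports only a limit, > 100000 nM, and no number. Compound 2 likewise reports only a limit, > 100000 nM. Both values sit at the limit of > 100000 nM in this assay, at which 2 of the 2 values shown sit, so compound 1 stands at the edge of what this assay reports, with no measured value to rank it against anything. Going by the values given here, the single measured step, a step that the two limits leave unreadable from compound 1 to compound 2, methylsulfanyl in place of methoxy on an aromatic carbon, is therefore unreadable in both size and direction.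

Compound 3 `COc1ccc(CNc2nc(S)nc3ccccc23)cc1` differs from compound 1 by one sulfur atom in place of a group of 2 heavy atoms (1 carbon, 1 selenium; no ring), on an aromatic carbon, in words one sulfur atom in place of a group of two heavy atoms (one carbon, one selenium; no ring), on an aromatic carbon between two ring nitrogen atoms of the shared core. Among the compounds with values here, no measured step concerns this position, and the one measured step cannot be read at all. Nothing shown points to a readable change in either direction; compound 3 is expected to sit near the same limit, with the step that the limit leaves unreadable from compound 1 to compound 3 from compound 1 to compound 3 carrying little weight. The estimate for compound 3 in this assay is 150000 nM, within 40000 nM to 600000 nM, most likely reported again only as a limit.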

Compound 3, concentration lethal to 50% of the cells: 63900 nM
Beside the measured number, compound 3's estimate is 2.3-fold (0.37 log units) above it, within the range that was stated.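

Going by these compounds alone, the swap of sulfanyl for the group of 2 heavy atoms (1 carbon, 1 selenium; no ring), on the aromatic carbon between two ring nitrogen atoms, gives the first measured number of the series in this assay: compound 3 gives 63900 nM. Going by these compounds, the step is an at least 1.5-fold lower number from compound 1 to compound 3 (0.19 log units; that floor lies within the scatter); this is a floor only, so the true size of the change stays unknown and may be larger than the floor, while the direction is the one thing the limit allows to be stated. Unlike the methylsulfanyl for methoxy change, which left the read-out unreadable, this change at this position brings a compound off the limit that holds the other two compounds: the limit of > 100000 nM in this assay, at which 2 of the 3 values shown sit.

The compounds shown leave open whether the number of compound 3 follows from the sulfanyl group itself or from the loss of the selenium-bearing group, a question that methylsulfanyl, an amine or a longer chain such as ethylsulfanyl at the same carbon would help to separate. Also open, on these data alone, is whether the same change on the core of compound 2 gives a similar number.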